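A few compounds are considered here, and "the series" means these few. Any claim that something is new, unique, unknown or untested is made for them only; others in the source may bear on it.

Of the compounds shown here, three sharing one core have been measured in a functional assay for inhibition of sodium/hydrogen exchanger (Oryctolagus cuniculus); a higher number here means a weaker inhibitor, a lower number a stronger inhibitor. Compound 1 `CCC(C)c1cc(C)c(C(=O)N=C(N)N)cc1S(C)(=O)=O` gives 8 nM. Compound 2 `Cc1cc(SC(C)C)c(S(C)(=O)=O)cc1C(=O)N=C(N)N` gives 12 nM, and compound 3 `Cc1cc(Oc2ccccc2)c(S(C)(=O)=O)cc1C(=O)N=C(N)N` gives 10 nM. The steps among them are small: a 1.5-fold higher number from compound 1 to compound 2 (0.18 log units; within the scatter), a 1.3-fold higher number from compound 1 to compound 3 (0.10 log units; within the scatter) and a 1.2-fold lower number from compound 2 to compound 3 (0.08 log units; within the scatter). Compound 3 thus stands with the second highest of the three numbers, compound 2 nearest and compound 1 furthest, all three within the scatter of one another. Compound 4 `Cc1cc(N2CCCC(O)C2)c(S(C)(=O)=O)cc1C(=O)N=C(N)N` differs from compound 3 in one place: 3-hydroxypiperidin-1-yl in place of phenoxy on an aromatic carbon. Within the data shown here, none of the measured steps brings in a ring with a nitrogen, so no step bears directly on this change; yet all three steps alter the same place of the core and all lie within the scatter, which shows that varied groups there have so far left this assay unchanged. Compound 4 is therefore expected to show no step beyond the scatter, a 1.5-fold higher number from compound 3 to compound 4 (0.18 log units; within the scatter), with a wider range because the entering group is new to the series. Compound 4 is estimated at 15 nM, between 5 nM and 50 nM.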

Compound 4, half-maximal inhibitory concentration: 30 nM
For compound 4 the middle estimate is 2.0-fold (0.30 log units) below the measured one; measured number inside the range.
By their numbers in this assay, from the lowest: compounds 1, 3 and 2 (each within the scatter of the next); then compound 4.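

In this assay, among these compounds, the place on the aromatic carbon ortho to a methylsulfonyl group proves not to be indifferent to what it carries: 3-hydroxypiperidin-1-yl is the first group there to move the number beyond the scatter, with a 3.0-fold higher number from compound 3 to compound 4 (0.48 log units; beyond the scatter), a 2.5-fold higher number from compound 2 to compound 4 (0.40 log units; beyond the scatter) and a 3.8-fold higher number from compound 1 to compound 4 (0.57 log units; beyond the scatter), all modest. Phenoxy and 3-hydroxypiperidin-1-yl have equal heavy-atom counts, so that count alone does not separate compound 3 from compound 4. Nothing at hand gives a cause for this step.

The change replaces an aromatic ring of carbon only with a non-aromatic ring holding a nitrogen and also brings in a hydroxyl, and the compounds shown do not tell these apart. Piperidin-1-yl without the hydroxyl would bear on that question, and so would cyclohexyl.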